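Fluorostilbene series: adding a fluoro to compound 3

The source may hold more compounds than are shown below. What is called first, only, known or untested is meant among the compounds shown, and "the series" means these compounds.

The series is read in an assay on HepG2 cells for activation of nuclear factor erythroid 2-related factor 2 (Homo sapiens), read by a luciferase reporter, with a stated time of 5 h; a higher number here means that more compound is needed for the effect, a lower number that less compound is needed. Compound 1 `Fc1cccc(/C=C/c2ccccc2F)c1` reaches only a limit of the assay, > 15000 nM. Compound 2 `Fc1cccc(/C=C/c2ccc(F)c(F)c2)c1` gives 5000 nM, and compound 3 `Fc1ccc(/C=C/c2cccc(F)c2)cc1` gives 650 nM. Among the two numbers compound 3 stands lowest; the single measured step, a 7.7-fold lower number from compound 2 to compound 3 (0.89 log units; beyond the scatter), removes a fluoro from the core. Compound 4 `Fc1cccc(/C=C/c2ccc(F)cc2F)c1` differs from compound 3 by fluoro in place of hydrogen on an aromatic carbon, a change of the opposite kind. Only a 7.7-fold lower number from compound 2 to compound 3 (0.89 log units; beyond the scatter) bears on it, and since that step lowered the number on taking a fluoro away, adding one is expected to raise the number in this assay by a modest amount. Compound 4 is expected to give 2000 nM, between 500 nM and 8000 nM, which means a 3.1-fold higher number from compound 3 to compound 4 (0.49 log units; beyond the scatter).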

Compound 4, half-maximal effective concentration: 450 nM
For compound 4 the middle estimate is 4.4-fold (0.65 log units) above the measured one, and the stated range ends above it.
By their numbers in this assay, from the lowest: compounds 4 and 3 (each within the scatter of the next); then compound 2. At a limit, above all of these: compound 1.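

On the core of compound 3, adding a fluoro to one aromatic carbon gives a 1.4-fold lower number from compound 3 to compound 4 (0.16 log units; within the scatter) in this assay, so a fluoro here leaves the number within the scatter. Compound 1 stands at a limit of the assay, so an at least 33-fold lower number from compound 1 to compound 4 (1.52 log units; beyond the scatter) gives only a bound: the limit of > 15000 nM in this assay, at which 1 of the 4 values shown sits. The same change does not carry one size of step from core to core: the same change on two cores in this assay, a 7.7-fold lower number (0.89 log units; beyond the scatter) from compound 2 to compound 3 and an at least 33-fold higher number (1.52 log units; beyond the scatter) from compound 4 to compound 1, at least 250-fold (2.40 log units) apart, beyond the scatter of two such steps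

From the compounds shown here alone, whether a hydroxyl or an amine on this aromatic carbon would stay within the scatter of compound 4 remains open. So does the true number for compound 1.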